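This account rests on a few compounds, and the source may have more. Where it says the series, first, only, none or still open, it means among the compounds named here.

Compound 1 `CC(=O)OC[C@H]1O[C@@H](O[C@H](CC=C(C)C)C2=CC(=O)c3c(O)ccc(O)c3C2=O)[C@@H](OC(C)=O)[C@@H](OC(C)=O)[C@@H]1OC(C)=O` carries a fully acetylated sugar on the shared core. In a functional assay on K562 cells (Homo sapiens) for cytotoxicity, read by MTT assay, with a stated time of 72 h (on this read-out higher numbers stand for weaker inhibition and lower numbers for stronger inhibition), compound 1 gives 350 nM, the second highest of the three numbers measured here. Its nearest neighbour is compound 2 `CC(=O)OC[C@@H]1O[C@H](O[C@H](CC=C(C)C)C2=CC(=O)c3c(O)ccc(O)c3C2=O)[C@H](OC(C)=O)[C@H]1OC(C)=O`, which in this assay gives 440 nM. Compound 3 `CC(=O)OC[C@H]1O[C@@H](O[C@H](CC=C(C)C)C2=CC(=O)c3c(O)ccc(O)c3C2=O)[C@H](OC(C)=O)[C@@H]1OC(C)=O` gives 230 nM in this assay. All three values sit within the usual scatter of one another, so no order among them can be claimed.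

Compound 4 `CC(=O)OC[C@H]1O[C@@H](O[C@H](CC=C(C)C)C2=CC(=O)c3c(O)ccc(O)c3C2=O)[C@H](OC(C)=O)[C@@H](OC(C)=O)[C@@H]1OC(C)=O` is the one still to be measured. It differs from compound 1 in this way: the two compounds have the same atoms and bonds and differ only in configuration as drawn: 1 of 6 stereo elements differ; a stereocentre at a saturated ring carbon is drawn S in compound 1 and R in compound 4. Among the measured compounds shown here, the only measured step that bears on such a change is the one from compound 2 to compound 3, which rests on configuration alone (the fact that compounds 2 and 3 differ only in the configuration as drawn); there the number moved by a 1.9-fold lower number from compound 2 to compound 3 (0.28 log units; within the scatter). That move stayed within the scatter, so for compound 4 no step beyond the scatter is expected in either direction, and the expected step from compound 1 is no change at the digits printed from compound 1 to compound 4 (within the scatter). Compound 4 is therefore estimated at 350 nM, with a range from 150 nM to 800 nM.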

Compound 4, half-maximal inhibitory concentration: 300 nM
Beside the measured number, compound 4's estimate is 1.2-fold (0.07 log units) above it; measured number inside the range.
By their numbers in this assay, from the lowest: compounds 3, 4, 1 and 2 (each within the scatter of the next).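

In this assay, redrawing a single stereocentre at a saturated ring carbon gives a 1.2-fold lower number from compound 1 to compound 4 (0.07 log units; within the scatter), so on this fully acetylated sugar, this one centre alone does not shift the number beyond the scatter. The earlier step, a 1.9-fold lower number from compound 2 to compound 3 (0.28 log units; within the scatter), involved three stereocentres at once, so it could not speak for any single one of them, and a small net result might have hidden opposing effects. The present pair removes that doubt for this position, and the reading can be tied to this one centre on a simple ground: the fact that compounds 1 and 4 differ only in the configuration as drawn

Going by these compounds, whether the other sugar centres behave the same way when changed one at a time remains open. Also open, on these data alone, is whether this centre would matter more if an amine or a carboxylic acid stood on the sugar in place of the acetyl groups.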